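Chloro for methoxy on the aryl ring of compound 2

The source may hold more compounds than are shown below. What is called first, only, known or untested is meant among the compounds shown, and "the series" means these compounds.

Compound 1 `CCCc1ccc(N2C(=O)NC3(CSC4=C3C(=O)c3ncccc3C4=O)C2=O)cc1`: 2 nM
Compound 2 `COc1ccc(N2C(=O)NC3(CSC4=C3C(=O)c3ncccc3C4=O)C2=O)cc1`: 10 nM
Compound 3 `O=C1NNC(=O)C2(CSC3=C2C(=O)c2ncccc2C3=O)N1`: 48 nM

These three compounds share one core and were all tested in a functional assay on CCRF-SB cells (Homo sapiens) for antiproliferative activity, read by MTT assay, with a stated time of 96 h; a higher number here means a weaker inhibitor, a lower number a stronger inhibitor. Compound 1 gives 2 nM and sits lowest. Compound 2 gives 10 nM and stands second highest of the three numbers: a 5.0-fold higher number from compound 1 to compound 2 (0.70 log units; beyond the scatter) separates it from compound 1, a modest step beyond the scatter, while compound 3, which lacks the aryl ring altogether, gives 48 nM and lies higher still.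

Compound 4 `O=C1C2=C(C(=O)c3ncccc31)C1(CS2)NC(=O)N(c2ccc(Cl)cc2)C1=O` is not yet measured. It differs from compound 2 in one place: chloro in place of methoxy on an aromatic carbon.

For the measured compounds named here, only one measured step touches the same aromatic carbon, the one from compound 1 to compound 2, where methoxy in place of propyl raised the number modestly. Chloro in place of methoxy is a different exchange, so that step is a loose guide at best. It suggests the group at this position moves the number by a modest amount, so a step of similar size or smaller is expected for compound 4, more likely downward than upward, though a result within the scatter would not surprise. The expected step is a 1.7-fold lower number from compound 2 to compound 4 (0.22 log units; within the scatter) for compound 4, giving an estimate of 6 nM, with a range from 2 nM to 18 nM.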

Compound 4, half-maximal inhibitory concentration: 10 nM
The estimate for compound 4 lay 1.7-fold (0.22 log units) below the measured number; the measured number falls inside the stated range.
By their numbers in this assay, from the lowest: compound 1; then compounds 2 and 4 (each within the scatter of the next); then compound 3.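

In this assay, 4-methoxyphenyl to 4-chlorophenyl gives no change at the digits printed from compound 2 to compound 4 (within the scatter) and so shows that, on this aromatic carbon para to a large group, two quite different substituents can read alike: methoxy carries one hydrogen-bond acceptor and chloro carries none. Propyl is what sets this position apart, since chloro in place of propyl gives a 5.0-fold higher number from compound 1 to compound 4 (0.70 log units; beyond the scatter) and matches the earlier step from propyl to methoxy, a 5.0-fold higher number from compound 1 to compound 2 (0.70 log units; beyond the scatter). This places compound 1 alone on one side and compounds 2 and 4 together on the other. No measurement at hand offers a reason for this grouping.

For the compounds shown here, with only three groups at this carbon, it remains open whether the lower number of compound 1 belongs to alkyl chains in general, and a longer chain such as butyl, or a shorter one such as ethyl, would test that. As far as these compounds go, it also remains open whether an amine or a carboxylic acid at the same carbon would read like methoxy and chloro or would move the number in either direction.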